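The source may hold more compounds than are shown below. What is called first, only, known or untested is meant among the compounds shown, and "the series" means these compounds.

Measured so far in a functional assay on NCI-H226 cells (Homo sapiens) for inhibition, read by sulforhodamine B assay, with a stated time of 48 h; a lower number here means a stronger inhibitor of growth, a higher number a weaker inhibitor of growth:
Compound 1 `COc1cc(-c2nn(-c3cccc(NC(=O)c4cccc(C(F)(F)F)c4)c3)cc2-c2ccncc2)ccc1Cl` gives 27000 nM.
Compound 2 `COc1cc(-c2nn(-c3cccc(NC(=O)Nc4cccc(C(F)(F)F)c4)c3)cc2-c2ccncc2)ccc1Cl` gives > 50000 nM, which is a limit of the assay and not a number.

Among the measured compounds shown here, compound 2 thus stands only at the limit of > 50000 nM in this assay, at which 1 of the 2 values shown sits, and the single measured step, an at least 1.8-fold higher number from compound 1 to compound 2 (0.26 log units; that floor lies within the scatter), gives a floor rather than a size. Compound 3 `COc1cc(-c2nn(-c3cccc(NC(=O)c4ccc(Cl)c(C(F)(F)F)c4)c3)cc2-c2ccncc2)ccc1Cl` is not yet measured. Its change from compound 2 is 4-chloro-3-(trifluoromethyl)phenyl in place of (3-(trifluoromethyl)phenyl)amino on a carbonyl carbon. For the measured compounds named here, this reverses the change of the measured step of an at least 1.8-fold higher number from compound 1 to compound 2 (0.26 log units; that floor lies within the scatter) and in addition brings in a chloro substituent, for which no measured step exists. The step of an at least 2.5-fold lower number from compound 2 to compound 3 (0.39 log units; beyond the scatter) in this assay is therefore expected to run toward a lower number, back to the region of compound 1, whose value 27000 nM is the nearest anchor. Compound 3 is accordingly estimated at 20000 nM, with a range from 7000 nM to 50000 nM.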

Compound 3, concentration for total growth inhibition: > 32500 nM
Compound 3 gave a limit, no number (the forecaster's own chance of this, stated with the estimate: 20%); middle value at least 1.6-fold (0.21 log units) away from the limit.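

In this assay compound 3, with 4-chloro-3-(trifluoromethyl)phenyl on the carbonyl carbon, gives > 32500 nM, which is a limit of the assay and not a number. Chloro in place of hydrogen on an aromatic carbon gives an at least 1.2-fold higher number from compound 1 to compound 3 (0.08 log units; that floor lies within the scatter), so the first measured chloro substituent in the series brings no sign of stronger growth inhibition, though the size of the step stays unknown. Compound 2 and compound 3 both stand at limits, and the step between them cannot be read.

Open, from the compounds shown here alone, is how far compound 3 lies beyond its limit, and whether chloro would have any effect alongside the (3-(trifluoromethyl)phenyl)amino group of compound 2. Also open, going by these compounds, is whether an amine or a carboxylic acid in the place of chloro would give a value inside the range of the assay.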